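Dropping One Chloro: What to Expect for Compound 3

The source may report more compounds than this note shows. Statements on the series, on what has been measured and on what is new or still open speak of the compounds shown alone.

Compound 1, `CCn1nc(Cc2ccc(Cl)cc2)c2ccccc2c1=O`, gives 1300 nM in a functional assay on aorta with Alpha-1D adrenergic receptor (Rattus norvegicus) as the target; a lower number here means that less compound is needed, a higher number that more compound is needed for the effect.
Compound 2, `Cn1nc(Cc2ccc(Cl)cc2Cl)c2ccccc2c1=O`, gives 1200 nM in this assay.

Compound 2 has the lowest of the two numbers, but compound 1 lies within the scatter of it, so the two cannot be ranked. Compound 3, `Cn1nc(Cc2ccc(Cl)cc2)c2ccccc2c1=O`, differs from compound 2 in one place: hydrogen in place of chloro on an aromatic carbon. Within the data shown here, no measured pair shows this single change on its own. Compound 1 also lacks this chloro, though it differs from compound 3 elsewhere, and compound 1 with 1300 nM sits close to compound 2. Among the measured compounds shown here, with only two values, both alike, there is no basis for expecting a step beyond the scatter. The step of a 1.3-fold higher number from compound 2 to compound 3 (0.12 log units; within the scatter) is therefore expected to be small, with a slight lean toward a higher number. Compound 3 is estimated at 1600 nM, within 700 nM to 3600 nM in this assay.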

Compound 3, half-maximal effective concentration: 430 nM
Beside the measured number, compound 3's estimate is 3.7-fold (0.57 log units) above it; the whole stated range lies above it.
By their numbers in this assay, from the lowest: compound 3; then compounds 2 and 1 (each within the scatter of the next).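

In this assay, hydrogen in place of chloro on an aromatic carbon, ortho to a large group, gives a 2.8-fold lower number from compound 2 to compound 3 (0.45 log units; beyond the scatter) and so shows that this chloro is not a silent passenger: the number moves beyond the scatter when it leaves. The group on the aromatic nitrogen matters as well, since hydrogen in place of methyl on a saturated chain carbon bound to that nitrogen gives a 3.0-fold lower number from compound 1 to compound 3 (0.48 log units; beyond the scatter) as a step of similar size. Compound 3 therefore has the lowest number of the three, and each of the two single changes leading to it reaches beyond the scatter.

On these data alone, whether a fluoro or methoxy group at the same aromatic carbon, or a propyl chain on the nitrogen, would follow the same direction remains open. Nothing available accounts for either step.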